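One swap on a compound at the assay limit

The compounds below may be only part of what the source reports. "The series", "measured", "known", "first", "only" and "open" are said of these compounds alone.

In a functional assay on A549 cells (Homo sapiens) for cytotoxicity, read by MTT assay, with a stated time of 48 h (on this read-out higher numbers stand for weaker inhibition and lower numbers for stronger inhibition), compound 1 (`COc1cc(-c2noc(N)c2-c2ccc(Cl)cc2)cc(OC)c1OC`) gives > 50000 nM as a limit of the assay. Compound 2 (`COc1ccc(-c2c(-c3cc(OC)c(OC)c(OC)c3)noc2N(C(C)=O)C(C)=O)cc1`) gives 430 nM as a true number. Compound 3 (`COc1ccc(-c2c(-c3cc(OC)c(OC)c(OC)c3)noc2N(C(C)=O)C(C)=O)cc1OC`) gives > 50000 nM as a limit too, so it has no exact place on the scale. Within the data shown here, the one measured step that bears on it is an at least 110-fold higher number from compound 2 to compound 3 (2.06 log units; beyond the scatter) with methoxy in place of hydrogen on an aromatic carbon. Compound 4 (`COc1cc(-c2noc(N(C(C)=O)C(C)=O)c2-c2ccc(Cl)cc2)cc(OC)c1OC`) carries the change 4-chlorophenyl in place of 3,4-dimethoxyphenyl on an aromatic carbon and so has 4-chlorophenyl in place of 3,4-dimethoxyphenyl on an aromatic carbon. It gives up the 3,4-dimethoxyphenyl of compound 3, and the large step of an at least 110-fold higher number from compound 2 to compound 3 (2.06 log units; beyond the scatter) suggests that part of that loss could return. Compound 1 also holds 4-chlorophenyl and still gives > 50000 nM as a limit, so that return is far from certain. A lower number is therefore expected, with an estimated size of an at least 33-fold lower number from compound 3 to compound 4 (1.52 log units; beyond the scatter) in this assay and wide uncertainty. The estimated value for compound 4 is 1500 nM ( expected range 150 nM to 30000 nM).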

Compound 4, half-maximal inhibitory concentration: > 50000 nM
Compound 4: a limit, no number (the forecaster's own chance of this, stated with the estimate: 25%); middle value at least 33-fold (1.52 log units) away from the limit.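

In this assay there is an at least 110-fold higher number from compound 2 to compound 4 (2.06 log units; beyond the scatter), with chloro in place of methoxy on an aromatic carbon. The loss is therefore not tied to the extra methoxy of compound 3: two different changes to the aromatic ring on this carbon of compound 2 both reach the limit. Among the three compounds carrying the diacetylamino group, only compound 2 gives a true number, 430 nM. The steps to compound 4 from compound 3 and from compound 1 cannot be read, because both ends of each step sit at the same limit: the limit of > 50000 nM in this assay, at which 3 of the 4 values shown sit.

As far as these compounds go, how far compound 3 and compound 4 lie beyond that limit remains unknown. Also open, from the compounds shown here alone, is whether a plain phenyl, or a 4-fluorophenyl or 4-methylphenyl group, on this carbon would give a true number.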